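Propoxy for tert-butyl on the aryl sulfonamide

The source may report more compounds than this note shows. Statements on the series, on what has been measured and on what is new or still open speak of the compounds shown alone.

Compound 1 `CC1CCN(C2CCN(S(=O)(=O)c3ccc(C(C)(C)C)cc3)CC2)CC1` is the weakest measured point of the set: in a functional assay on DLD-1 cells (Homo sapiens) for antiproliferative activity, read by CellTiter-Glo, with a stated time of 72 h (a higher number here means a weaker inhibitor, a lower number a stronger inhibitor), compound 1 gives only the limit > 5000 nM, which is a limit of the assay and not a number (the limit of > 5000 nM in this assay, at which 1 of the 3 values shown sits). For comparison, compound 2 `CC1CCN(C2CCN(S(=O)(=O)c3cc(Br)cc4c3OCC4)CC2)CC1` gives 96 nM in this assay and compound 3 `Cc1cc(C)c(S(=O)(=O)N2CCC(N3CCC(C(C)C)CC3)CC2)c(C)c1` gives 0.3 nM. The compound to be tested, compound 4 `CCCOc1ccc(S(=O)(=O)N2CCC(N3CCC(C)CC3)CC2)cc1`, differs from compound 1 by propoxy in place of tert-butyl on an aromatic carbon. Within the data shown here, no pair of measured compounds differs in a single place, so no measured step guides this change; the expectation is a step from compound 1 to compound 4 of no more than the usual scatter, perhaps a modest gain an at least 1.6-fold lower number from compound 1 to compound 4 (0.22 log units; that floor lies within the scatter). Compound 4 is therefore estimated at 3000 nM, within 400 nM to 20000 nM.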

Compound 4, half-maximal inhibitory concentration: 452 nM
The estimate for compound 4 lay 6.6-fold (0.82 log units) above the measured number, and the stated range covers the measured number.
By their numbers in this assay, from the lowest: compound 3; then compound 2; then compound 4. At a limit, above all of these: compound 1.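

At the aromatic carbon para to a large group, the position proves sensitive to the group it carries: in this assay, propoxy in place of tert-butyl gives an at least 11-fold lower number from compound 1 to compound 4 (1.04 log units; beyond the scatter). The heavy-atom count stays the same, with an oxygen entering the substituent. The size of this step is only a bound, since compound 1 stands at a limit and not at a number: the limit of > 5000 nM in this assay, at which 1 of the 4 values shown sits.

As far as these compounds go, whether the oxygen or the unbranched chain carries the gain remains open. A butyl chain, methoxy or a longer alkoxy chain at this position would separate the two.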